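Moving a chlorine onto the pendant ring of the core

The source may hold more compounds than are shown below. What is called first, only, known or untested is meant among the compounds shown, and "the series" means these compounds.

Compound 1 `C=CCn1c(=O)/c(=C\c2cccc(Cl)c2)[nH]c(=O)/c1=C\c1ccccc1OC`: 5100 nM
Compound 2 `C=CCn1c(=O)/c(=C\c2ccc(C)cc2)[nH]c(=O)/c1=C\c1ccccc1OC`: "not active" (no number reported)

In a functional assay on NCI-H1975 cells (Homo sapiens) for cytotoxicity, read by CCK-8 assay, with a stated time of 72 h (a lower number here means a stronger inhibitor, a higher number a weaker inhibitor), compound 1 gives 5100 nM. Compound 2 is reported in this assay as "not active" (no number reported), so no number fixes where compound 2 stands; it is simply without a reported value. Compound 3 `C=CCn1c(=O)/c(=C\c2ccccc2Cl)[nH]c(=O)/c1=C\c1ccccc1OC` differs from compound 2 in one place: 2-chlorophenyl in place of 4-methylphenyl on a double-bonded chain carbon bound to an aromatic carbon. Going by the values given here, with no measured step for this change, the expectation rests on compound 1, whose 5100 nM shows that a chlorine on this ring can give a measurable number; a modest improvement from compound 2 to a reportable value is expected, though compound 3 may also come back without a reported number. Compound 3 is expected at 8000 nM, within 2000 nM to 40000 nM.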

Compound 3, half-maximal inhibitory concentration: 9200 nM
Compound 3: the middle estimate sits 1.2-fold (0.06 log units) below what was measured; low and high end bracket the measured number.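

Compound 3 shows that 2-chlorophenyl, like 3-chlorophenyl, gives a reported number in this assay at this position, whereas compound 2, with 4-methylphenyl, has none. The exchange of one chlorophenyl for the other gives a 1.8-fold higher number from compound 1 to compound 3 (0.26 log units; within the scatter) so the two cannot be ranked. No evidence accompanies these results to explain them.

As far as these compounds go, whether compound 2 lacks a number through its methyl group or through that group's place remains open, since neither 4-chlorophenyl nor 2-methylphenyl appears here. From the compounds shown here alone, how a phenyl ring carrying an amine or a carboxylic acid would behave also remains unknown.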